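Swapping a Chlorophenyl Ring for Cyclopropyl in Hydroxamate Inhibitors

This account rests on a few compounds, and the source may have more. Where it says the series, first, only, none or still open, it means among the compounds named here.

Compound 1, `O=C(CCCCCn1cc(Nc2ncc3ccn(Cc4ccccc4)c3n2)cn1)NO`: 13.8 nM
Compound 2, `O=C(CCCCCn1cc(Nc2ncc3ccn(Cc4ccccc4Cl)c3n2)cn1)NO`: 45 nM
Compound 3, `O=C(CCCCCCn1cc(Nc2ncc3ccn(Cc4ccccc4Cl)c3n2)cn1)NO`: 41.5 nM

The numbers above come from an assay on isolated protein for inhibition of protein deacetylase HDAC6 (Homo sapiens), with a stated time of 60 min; a higher number here means a weaker inhibitor, a lower number a stronger inhibitor. Among the three measured compounds, compound 3 gives the second highest number. Its closest neighbour is compound 2, and the step of a 1.1-fold lower number from compound 2 to compound 3 (0.04 log units; within the scatter) shows that lengthening the chain made no real difference. The furthest away is compound 1; the step of a 3.3-fold higher number from compound 1 to compound 2 (0.51 log units; beyond the scatter) shows that adding a chlorine to the ring weakened inhibition by a modest but real amount.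

Compound 4, `O=C(CCCCCCn1cc(Nc2ncc3ccn(CC4CC4)c3n2)cn1)NO`, differs from compound 3 by cyclopropyl in place of 2-chlorophenyl on a saturated chain carbon bound to an aromatic nitrogen. No measured step replaces the ring itself, so nothing shown tells directly what this change does. Going by the values given here, the one step that touches this part of the molecule, a 3.3-fold higher number from compound 1 to compound 2 (0.51 log units; beyond the scatter), shows the region is sensitive, yet gives no direction for swapping the whole ring. Compound 4 is therefore expected to give about 38 nM, in a wide range from 12 nM to 130 nM. This estimate amounts to a step of a 1.1-fold lower number from compound 3 to compound 4 (0.04 log units; within the scatter), within the scatter of compound 3.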

Compound 4, half-maximal inhibitory concentration: 16 nM
Compound 4: middle estimate off by 2.4-fold (0.38 log units), on the high side; the range from low to high includes it.
By their numbers in this assay, from the lowest: compounds 1 and 4 (each within the scatter of the next); then compounds 3 and 2 (each within the scatter of the next).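

Compound 4 shows that the 2-chlorophenyl ring can be given up at this position: in this assay, putting cyclopropyl in its place gives a 2.6-fold lower number from compound 3 to compound 4 (0.41 log units; beyond the scatter). The earlier compounds shown here showed only that adding a chlorine to the ring weakened inhibition, whereas here a group of three heavy atoms, with no aromatic ring, does better than one of seven. Nothing available explains why this swap strengthens inhibition.

This step removes the chlorine and the aromatic ring together, so the compounds shown cannot tell which loss matters, and a plain benzyl group on the longer chain would separate the two. As far as these compounds go, it also remains open whether a smaller methyl group, a larger cyclohexyl ring or an amine would do as well on this carbon.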